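Compound 3 to compound 4: a pyridin-3-yl exchange

The source may hold more compounds than are shown below. What is called first, only, known or untested is meant among the compounds shown, and "the series" means these compounds.

Of the compounds shown here, three with a shared core have been measured in a functional assay for inhibition, with Homo sapiens as the target; a lower number here means tighter binding, a higher number weaker binding. Compound 1 `N#Cc1ccccc1C1OCC(C/C=C\CCC(=O)O)C(c2cccnc2)O1` gives 245 nM, compound 2 `O=C(O)CC/C=C\CC1COC(c2ccc(Cl)cc2Cl)OC1c1cccnc1` gives 891 nM, and compound 3 `O=C(O)CC/C=C\CC1COC(c2ccc(C(F)(F)F)cc2)OC1c1cccnc1` gives 1780 nM. Compound 3 therefore stands at the upper end of these numbers, but not apart from the nearest measured compound, as a 2.0-fold higher number from compound 2 to compound 3 (0.30 log units; within the scatter) shows. The gap to the other measured compound is larger, with a 7.3-fold higher number from compound 1 to compound 3 (0.86 log units; beyond the scatter).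

The next compound, compound 4 `O=C(O)CC/C=C\CC1COC(c2cccnc2)OC1c1cccnc1`, carries pyridin-3-yl in place of 4-(trifluoromethyl)phenyl on a saturated ring carbon, between two ring oxygen atoms (pyridin-3-yl in place of 4-(trifluoromethyl)phenyl on a saturated ring carbon). All three measured steps concern this same place. Beyond the two already given, there is a 3.6-fold higher number from compound 1 to compound 2 (0.56 log units; beyond the scatter). These steps are small to modest, and none of them involves pyridin-3-yl at this place, so they offer only a general guide to the likely size of the change. On that basis, no shift beyond the scatter is expected in this assay, though one of modest size in either direction remains possible. The expected change is a 1.2-fold lower number from compound 3 to compound 4 (0.07 log units; within the scatter). For compound 4 the estimated value is 1500 nM, with an expected range from 450 nM to 5000 nM.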

Compound 4, dissociation constant: 759 nM
Beside the measured number, compound 4's estimate is 2.0-fold (0.30 log units) above it; low and high end bracket the measured number.
By their numbers in this assay, from the lowest: compound 1; then compounds 4, 2 and 3 (each within the scatter of the next, the first and the last beyond it).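

In this assay, within the data shown here, pyridin-3-yl, with one hetero atom in its ring and 6 heavy atoms, in place of 4-(trifluoromethyl)phenyl gives a 2.3-fold lower number from compound 3 to compound 4 (0.37 log units; beyond the scatter), the first evidence at this saturated ring carbon, between two ring oxygen atoms, that a six-membered aromatic ring of carbon only is not required to keep the number in this range. The same exchange made against 2,4-dichlorophenyl gives a 1.2-fold lower number from compound 2 to compound 4 (0.07 log units; within the scatter), while the exchange against 2-cyanophenyl gives a 3.1-fold higher number from compound 1 to compound 4 (0.49 log units; beyond the scatter), so 2-cyanophenyl still stands apart, with compound 1 beyond the scatter of each of the other three compounds. No evidence at hand accounts for these differences.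

The compounds shown leave open how much of the step from compound 3 to compound 4 belongs to the ring nitrogen and how much to the loss of the trifluoromethyl group; an unsubstituted phenyl group at this place would separate the two. Also open, from the compounds shown here alone, is whether a nitrile on the pyridin-3-yl ring would bring the number close to that of compound 1, or whether the nitrile in compound 1 counts only on a phenyl ring.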